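The source may report more compounds than this note shows. Statements on the series, on what has been measured and on what is new or still open speak of the compounds shown alone.

Compound 1 `Oc1cccc(-c2cc(-c3cccs3)nc(-c3ccccc3Cl)c2)c1`: in an assay on isolated protein for inhibition of DNA topoisomerase 1 (Homo sapiens), with a stated time of 30 min, tested at 100 uM (a lower number here means a weaker effect, a higher number a stronger effect of the compound at the concentration tested), compound 1 gives 2.7%.
Compound 2 `Oc1cccc(-c2cc(-c3ccccn3)nc(-c3ccccc3Cl)c2)c1`: in this assay compound 2 gives 0%.
Compound 3 `Oc1cccc(-c2cc(-c3ccccc3)nc(-c3ccccc3Cl)c2)c1`: in this assay compound 3 gives 3.2%.

The three compounds share one core and differ only in the ring attached to one aromatic carbon of it. Compound 3 shows the highest of the three numbers, yet neither neighbour is separated from it by more than the scatter: a number 0.5 percentage points higher from compound 1 to compound 3 (within the scatter) and a number 3.2 percentage points higher from compound 2 to compound 3 (within the scatter) are both small. The remaining exchange, a number 2.7 percentage points lower from compound 1 to compound 2 (within the scatter), also stays within the scatter, so none of the three rings tried so far moves the read-out in a way that can be trusted.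

Compound 4 `Oc1cccc(-c2cc(-c3ccncc3)nc(-c3ccccc3Cl)c2)c1` continues this series: pyridin-4-yl in place of phenyl on an aromatic carbon. The closest measured step is a number 3.2 percentage points higher from compound 2 to compound 3 (within the scatter), where a pyridyl ring and phenyl changed places without a trustworthy effect, and a number 0.5 percentage points higher from compound 1 to compound 3 (within the scatter) points the same way. The expected outcome for compound 4 in this assay is therefore no step beyond the scatter, a number 0.2 percentage points lower from compound 3 to compound 4 (within the scatter). Compound 4 is estimated at 3%, with a range from 0% to 12%.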

Compound 4, a percentage reported as inhibition, at one concentration (the size of the read-out at that concentration, not a potency): 0%
Estimate against measurement, compound 4: 3 percentage points above, within the range that was stated.
By their numbers in this assay, from the lowest: compounds 2, 4, 1 and 3 (each within the scatter of the next).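

Moving the ring nitrogen to a different place within the pyridine ring leaves this assay unaffected, with pyridin-4-yl in place of pyridin-2-yl giving no change at the digits printed from compound 2 to compound 4 (within the scatter). Pyridin-4-yl brings one hydrogen-bond acceptor where phenyl has none, yet the exchange gives only a number 3.2 percentage points lower from compound 3 to compound 4 (within the scatter), and replacing thiophen-2-yl gives a number 2.7 percentage points lower from compound 1 to compound 4 (within the scatter), so this position has now tolerated four aromatic rings with no step beyond the scatter. No supporting measurement is available to explain this result.

Going by these compounds, all four compounds keep an aromatic ring at this position, so it remains open whether an amine, a carboxylic acid or a longer alkyl chain there would give a clearer read-out. Also open, on these data alone, is whether changing the 3-hydroxyphenyl or 2-chlorophenyl group would do so.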